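The source may report more compounds than this note shows. Statements on the series, on what has been measured and on what is new or still open speak of the compounds shown alone.

Compound 1 `CNC(=O)c1cc(C(=O)NCCCC2CNCCO2)cn(Cc2ccccc2)c1=O` was measured in a physicochemical assay for solubility; a higher number here means a more soluble compound, a lower number a less soluble compound. In this assay compound 1 gives >= 194 ug/mL, which is a limit of the assay rather than a number; it sits at the limit of >= 194 ug/mL in this assay, at which 1 of the 2 values shown sits. Compound 2 `CNC(=O)c1cc(C(=O)NC2CC2)cn(Cc2cccc3[nH]c(C)nc23)c1=O` was measured in the same way. In this assay compound 2 gives >= 198 ug/mL, again a limit rather than a number, sitting at the limit of >= 198 ug/mL in this assay, at which 1 of the 2 values shown sits. Both values being limits, compound 1 cannot be ordered against compound 2; all that is known is that each reaches the top of what this assay reports. Compound 3 `CNC(=O)c1cc(C(=O)NC2CCC2)cn(Cc2ccccc2)c1=O` has not yet been measured in this assay. It differs from compound 1 in one place: cyclobutyl in place of 3-(morpholin-2-yl)propyl on an amide-type nitrogen. Among the measured compounds shown here, no measured pair shows what such a change does in this assay, so the size of the step has to be guessed from the structures alone. The step expected in this assay, an at least 2.7-fold lower number from compound 1 to compound 3 (0.44 log units; beyond the scatter), is a drop that would go beyond the usual scatter. Compound 3 is therefore estimated at 70 ug/mL, with a likely range from 15 ug/mL to 200 ug/mL.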

Compound 3, solubility: 28 ug/mL
Compound 3: middle estimate off by 2.5-fold (0.40 log units), on the high side, and the stated range covers the measured number.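

This result gives a readable step at this position, which the two limits alone could not: in this assay, cyclobutyl in place of 3-(morpholin-2-yl)propyl on the amide-type nitrogen gives an at least 6.9-fold lower number from compound 1 to compound 3 (0.84 log units; beyond the scatter). What sits on this nitrogen can therefore move the number by more than the usual scatter, while the rest of the molecule stays the same. The step is only a minimum, and the real drop could be larger, because the value for compound 1 is a limit of the assay and not a number: the limit of >= 194 ug/mL in this assay, at which 1 of the 3 values shown sits.

The change swaps several features at once, since the morpholine ring, its nitrogen and oxygen, and the three-carbon chain all leave together, so the compounds shown cannot say which of these accounts for the drop. A plain propyl chain would test the chain without the ring, and a morpholine ring joined through a shorter chain or a cyclobutyl ring carrying an amine would test the ring and its nitrogen, so that each part of the step could be read on its own.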